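Chloro in Place of Methyl on a Shared Core

The source may hold more compounds than are shown below. What is called first, only, known or untested is meant among the compounds shown, and "the series" means these compounds.

Of the compounds shown here, two with a shared core have been tested in a toxicity assay on the whole organism with Rattus norvegicus as the target, at a dose of 200 mg/kg by the oral route; on this read-out higher numbers stand for a stronger effect at the one dose given and lower numbers for a weaker effect. Compound 1, `Brc1ccccc1OCC1=NCCO1`, gives 20%. Compound 2, `Cc1ccccc1OCC1=NCCO1`, gives 20%. Going by the values given here, the single step between them, no change at the digits printed from compound 1 to compound 2 (within the scatter), leaves the read-out where it was, so compound 2 stands level with compound 1 on this assay.

Compound 3, `Clc1ccccc1OCC1=NCCO1`, has not yet been measured. It differs from compound 2 in one place: chloro in place of methyl on an aromatic carbon. Among the compounds with values here, the only measured step that bears on this change is the one putting methyl in place of bromo on an aromatic carbon, which in no change at the digits printed from compound 1 to compound 2 (within the scatter) stayed within the scatter. Exchanging one small group for another at that place therefore gives no reason to expect movement beyond the scatter in this assay. For compound 3 the expected step is no change at the digits printed from compound 2 to compound 3 (within the scatter). Compound 3 is estimated at 20%, with a range from 5% to 40%.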

Compound 3, a percentage reported as activity, at one dose (the size of the read-out at that dose, not a potency): 30%
The estimate for compound 3 lay 10 percentage points below the measured number; the range from low to high includes it.
By their numbers in this assay, from the lowest: compounds 1, 2 and 3 (each within the scatter of the next).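

With chloro added, three different groups have now been read at this one place, on an aromatic carbon ortho to a group of 7 heavy atoms, in this assay. Chloro in place of methyl gives a number 10 percentage points higher from compound 2 to compound 3 (within the scatter), and chloro in place of bromo gives a number 10 percentage points higher from compound 1 to compound 3 (within the scatter), so neither step separates the compounds, and methyl, bromo and chloro cannot be told apart at this place at the one dose given. No measurement at hand offers an explanation for these numbers.

As far as these compounds go, whether a group of another kind at this place, such as an amine or a carboxylic acid, would move the read-out beyond the scatter stays open. So does how these compounds would compare at any other dose.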